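Fluorine position on the benzyl ether of compound 1

The source may report more compounds than this note shows. Statements on the series, on what has been measured and on what is new or still open speak of the compounds shown alone.

Measured so far in an assay for inhibition of dual specificity protein phosphatase 26 (Homo sapiens), read by fluorescence, with a stated time of 30 min; on this read-out higher numbers stand for weaker inhibition and lower numbers for stronger inhibition:
compound 1 `CN1C(=O)/C(=C/c2ccc(OCc3ccc(F)cc3)cc2)S/C1=N/c1cccc(C(=O)O)c1`: 26900 nM
compound 2 `O=C(O)c1cccc(N2C(=O)/C(=C\c3ccc(O)c(O)c3)SC2=S)c1`: 25100 nM
compound 3 `O=C(O)c1ccc(Cl)cc1Nc1nc2ccccc2nc1NS(=O)(=O)c1ccc(Cl)cc1`: 17000 nM

Compound 1 carries the highest of the three numbers, but its gap to compound 2 and its gap to compound 3 both stay within the usual scatter, so the three compounds cannot be ordered against one another on this read-out. Within the data shown here, none of the three pairs differs in a single place, so no isolated structural step is available from the measured set.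

Compound 4 `CN1C(=O)/C(=C/c2ccc(OCc3cccc(F)c3)cc2)S/C1=N/c1cccc(C(=O)O)c1` is the next compound of the shared core of compound 1. It differs from compound 1 only in that (3-fluorophenyl in place of 4-fluorophenyl on a saturated chain carbon bound to an oxygen on an aromatic ring). No comparable change has been measured in this assay. Among the measured compounds shown here, with no reference step to lean on, the expectation is a step from compound 1 to compound 4 of a 1.0-fold higher number from compound 1 to compound 4 (0.00 log units; within the scatter), that is, no change beyond the scatter in either direction. Compound 4 is therefore estimated at 27000 nM, with a range of 11000 nM to 65000 nM.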

Compound 4, half-maximal inhibitory concentration: 12500 nM
Estimate against measurement, compound 4: 2.2-fold (0.33 log units) above; measured number inside the range.
By their numbers in this assay, from the lowest: compounds 4, 3, 2 and 1 (each within the scatter of the next, the first and the last beyond it).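

In this assay, 3-fluorophenyl in place of 4-fluorophenyl on a saturated chain carbon bound to an oxygen on an aromatic ring gives a 2.2-fold lower number from compound 1 to compound 4 (0.33 log units; beyond the scatter), a modest step beyond the scatter. Among these compounds, this is the first isolated step, and it shows that the read-out responds at this position to the placement of the fluorine alone, since the two compounds have the same atoms, joined differently. Nothing on hand accounts for the step.

On these data alone, whether the lower number depends on fluorine itself remains open, as a single pair cannot separate the effect of the atom from that of its placement. An unsubstituted benzyl group or a chlorobenzyl group on the same oxygen would test how far this step extends within the shared core.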